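The source may report more compounds than this note shows. Statements on the series, on what has been measured and on what is new or still open speak of the compounds shown alone.

Three compounds share one core and differ only in how methoxy groups sit on the ring at the end of the chain. Compound 1 `C=C(Br)C(=O)Nc1ccc(C(=O)/C=C/c2cccc(OC)c2)cc1` in a functional assay on FM3A cells (Mus musculus) for antiproliferative activity, with a stated time of 48 h (a higher number here means a weaker inhibitor, a lower number a stronger inhibitor), gives 1800 nM. Compound 2 `C=C(Br)C(=O)Nc1ccc(C(=O)/C=C/c2ccccc2OC)cc1` gives 370 nM, the lowest number of the three, and compound 3 `C=C(Br)C(=O)Nc1ccc(C(=O)/C=C/c2ccc(OC)c(OC)c2)cc1` gives 1200 nM. The difference between compound 1 and compound 2 is 2-methoxyphenyl in place of 3-methoxyphenyl on a double-bonded chain carbon bound to a double-bonded chain carbon; it made a 4.9-fold lower number from compound 1 to compound 2 (0.69 log units; beyond the scatter). The difference between compound 1 and compound 3 is methoxy in place of hydrogen on an aromatic carbon; it made a 1.5-fold lower number from compound 1 to compound 3 (0.18 log units; within the scatter). Compound 4 `C=C(Br)C(=O)Nc1ccc(C(=O)/C=C/c2ccc(OC)cc2OC)cc1` is not yet measured. Its difference from compound 2 is methoxy in place of hydrogen on an aromatic carbon. Within the data shown here, this is the same kind of change as the one from compound 1 to compound 3, but not the same: there the entering methoxy sat ortho to a methoxy group, here it sits meta to a methoxy group, in both cases para to a large group. Because a 1.5-fold lower number from compound 1 to compound 3 (0.18 log units; within the scatter) lay within the scatter, the expected step in this assay is a 1.2-fold lower number from compound 2 to compound 4 (0.09 log units; within the scatter). The estimate for compound 4 in this assay is 300 nM, expected to fall between 120 nM and 800 nM.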

Compound 4, half-maximal inhibitory concentration: 1200 nM
The estimate for compound 4 lay 4.0-fold (0.60 log units) below the measured number; measured number outside the range, above it.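

In this assay, methoxy in place of hydrogen on an aromatic carbon gave a 3.2-fold higher number from compound 2 to compound 4 (0.51 log units; beyond the scatter). Set beside the earlier use of this change, the step did not carry over from one core to the other: the same change on two cores in this assay, a 1.5-fold lower number (0.18 log units; within the scatter) from compound 1 to compound 3 and a 3.2-fold higher number (0.51 log units; beyond the scatter) from compound 2 to compound 4, 4.9-fold (0.69 log units) apart, beyond the scatter of two such steps. This shows that, for these two cases, the result of adding a methoxy group on one core could not simply be copied to the other, but it does not show why, and two steps make no general rule; the entering group also sits in a different place relative to the methoxy group already present, so the effect of the core cannot be separated from the effect of position.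

What the compounds shown leave open is how a different group in the place taken by the new methoxy of compound 4, such as a fluorine atom, a hydroxyl or an amine, would compare with it. Also open, on these data alone, is whether a longer chain there, such as ethoxy, would follow compound 4.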